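A few compounds are considered here, and "the series" means these few. Any claim that something is new, unique, unknown or untested is made for them only; others in the source may bear on it.

Working notes on the series. Going by the values given here, in a functional assay on cells (Prostatic carcinoma cell, Homo sapiens) for cytotoxicity, read by sulforhodamine B assay, with a stated time of 48 h (a lower number here means a stronger inhibitor of growth, a higher number a weaker inhibitor of growth), only two compounds have numbers so far. Compound 1 (`COc1ccc2c(c1)/C(=C/c1c(-c3ccncc3)nc3sccn13)C(=O)N2C`) gives 68800 nM, and compound 2 (`COc1ccc2c(c1)/C(=C\c1c(OC)nc3sc(C)cn13)C(=O)N2`) gives 52800 nM. These two values lie within the scatter of each other, so neither compound can be ranked ahead of the other.

The next compound is compound 3 (`COc1nc2sc(C)cn2c1/C=C1/C(=O)Nc2ccccc21`), whose difference from compound 2 is hydrogen in place of methoxy on an aromatic carbon. Hydrogen stands in place of methoxy on an aromatic carbon, and nothing else changes. Among the compounds with values here, no comparison between measured compounds that differ in one place is available, so the data give no direct measure of what removing this methoxy does in this assay.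

A change beyond the scatter is not expected, and neither direction is favoured. The expectation takes compound 2 at 52800 nM as its starting point. The expected change is small, with a 1.1-fold lower number from compound 2 to compound 3 (0.02 log units; within the scatter) as the estimated step. For compound 3 the estimated value is 50000 nM, with an expected range of 22000 nM to 100000 nM.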

Compound 3, concentration for total growth inhibition: 45000 nM
Estimate against measurement, compound 3: 1.1-fold (0.05 log units) above; the measured number falls inside the stated range.
By their numbers in this assay, from the lowest: compounds 3, 2 and 1 (each within the scatter of the next).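

In this assay, going by these compounds alone, hydrogen in place of methoxy on an aromatic carbon of a six-membered aromatic ring of carbon only, part of a fused or bridged system of two rings, gives a 1.2-fold lower number from compound 2 to compound 3 (0.07 log units; within the scatter) and provides the first direct reading at this position. On this core, therefore, the methoxy can be removed with no change beyond the scatter, and growth inhibition stays in the same range without it. No separate measurement bears on the reason for this result.

On these data alone, the result covers only methoxy and hydrogen at this carbon, so it remains open whether an amine, a carboxylic acid or a longer alkoxy chain there would give a change beyond the scatter in this assay. As far as these compounds go, it is also open whether the same replacement would behave in the same way on the core of compound 1, which differs from compound 2 in more than one place.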